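Moving the nitrile on the aryl group of compound 1

The source may report more compounds than this note shows. Statements on the series, on what has been measured and on what is new or still open speak of the compounds shown alone.

In a functional assay on SK-N-SH cells (Homo sapiens) for inhibition, read by MTT assay, with a stated time of 72 h, tested at 30 uM (a higher number here means more inhibition of growth at the concentration tested, a lower number less inhibition of growth), compound 1 `C=CCc1ccc(OCc2cn(-c3ccc(C#N)cc3)nn2)c(O)c1` gives 37.5% at the concentration tested. Compound 2 `C=CCc1ccc(OCc2cn(-c3cc(OC)c(OC)c(OC)c3)nn2)c(O)c1` gives 44.1% in this assay and lies within the scatter of compound 1. Compound 3 `C#CCOc1ccc(CC=C)cc1O` gives 11.8% in this assay and lies beyond the scatter from compound 1, on the low side. Compound 1 therefore stands with compound 2 and clear of compound 3.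

Compound 4 `C=CCc1ccc(OCc2cn(-c3cccc(C#N)c3)nn2)c(O)c1` has the same atoms as compound 1, joined differently: 3-cyanophenyl in place of 4-cyanophenyl on an aromatic nitrogen describes 3-cyanophenyl in place of 4-cyanophenyl on an aromatic nitrogen. Among the compounds with values here, no measured pair shows a change of this kind, so the size of the step cannot be read directly. Compound 1 with 37.5% and compound 2 with 44.1% carry different groups on that aromatic nitrogen, yet they lie within the scatter of each other, and this is the ground for expecting only a small change. The estimated step of a number 0.5 percentage points higher from compound 1 to compound 4 (within the scatter) is expected to stay within the scatter, with neither direction favoured. The estimate for compound 4 is 38% as the expected value, with an expected range from 26% to 50% in this assay.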

Compound 4, percent growth inhibition at one concentration: 21.2%
Estimate against measurement, compound 4: 16.8 percentage points above, outside the stated range (below it).
By their numbers in this assay, from the lowest: compounds 3 and 4 (each within the scatter of the next); then compounds 1 and 2 (each within the scatter of the next).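

Within this assay, replacing 4-cyanophenyl with 3-cyanophenyl on the aromatic nitrogen gives a number 16.3 percentage points lower from compound 1 to compound 4 (beyond the scatter) even though the two groups have the same atoms and the same counts under comparison. Within the data shown here, this is the first direct reading at this position, since the earlier compounds formed no pair differing in one place, and the values of compound 1 and compound 2 could say nothing about where the nitrile sits on the phenyl group. The result therefore shows that moving the nitrile alone, with nothing added or removed, is enough to give a step of modest size beyond the scatter, while nothing available here bears on the reason for it.

The compounds shown leave open whether this dependence on placement belongs to the nitrile or would also appear with another group on the phenyl group, such as a carboxylic acid or an amine. They also leave open whether the same step would appear on the shared core with the allyl chain replaced by a longer chain.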